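The source may report more compounds than this note shows. Statements on the series, on what has been measured and on what is new or still open speak of the compounds shown alone.

Working notes on the series.

Compound 1 `COc1ccc(CSc2nc(Cc3cccc(Br)c3)c(C)c(=O)[nH]2)cc1` carries a methoxy on the benzylsulfanyl ring. In an ADME assay on MT4 cells (Homo sapiens) for cytotoxicity, read by MTT assay (on this read-out higher numbers stand for lower toxicity in this test and lower numbers for higher toxicity in this test), compound 1 reaches only a limit of > 290000 nM. Compound 2 `Cc1c(Cc2cccc(Br)c2)nc(SCc2ccc([N+](=O)[O-])cc2)[nH]c1=O` differs from compound 1 by nitro in place of methoxy on an aromatic carbon. In this assay compound 2 likewise reaches only a limit of > 280000 nM. The step that the two limits leave unreadable from compound 1 to compound 2 therefore cannot be read, since both values sit at limits, as the limit of > 290000 nM in this assay, at which 1 of the 3 values shown sits, and the limit of > 280000 nM in this assay, at which 1 of the 3 values shown sits, record.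

Compound 3 `COc1ccc(CSc2nc(Cc3cc(C(F)(F)F)cc(C(F)(F)F)c3)c(C)c(=O)[nH]2)cc1` carries the same methoxy group on a core that differs from the core of compound 1; that difference between the two cores is not broken down here. In this assay compound 3 again reaches only a limit of > 256000 nM, as the limit of > 256000 nM in this assay, at which 1 of the 3 values shown sits, records.

Going by the values given here, compound 4 `Cc1c(Cc2cc(C(F)(F)F)cc(C(F)(F)F)c2)nc(SCc2ccc([N+](=O)[O-])cc2)[nH]c1=O` differs from compound 3 by nitro in place of methoxy on an aromatic carbon, the same change as the one from compound 1 to compound 2, at the same place. No readable step exists for that change. Compound 4 is expected to sit at or above the limit again, a step that the limit leaves unreadable from compound 3 to compound 4. The estimate for compound 4 is 280000 nM, in the range 120000 nM to 500000 nM.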

Compound 4, half-maximal cytotoxic concentration: > 248000 nM
Compound 4 ended at the assay's limit; the forecaster's own chance of this, stated with the estimate: 80%; the middle value is on the limit's open side.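

In this assay compound 4 reaches only a limit of > 248000 nM. Going by these compounds alone, with compound 3 also at a limit, no step from compound 3 to compound 4 can be read. The compounds shown leave open whether nitro in place of methoxy on an aromatic carbon shifts the read-out in this assay on either core.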